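From chloro to methoxy in compound 4

This account rests on a few compounds, and the source may have more. Where it says the series, first, only, none or still open, it means among the compounds named here.

compound 1 `O=C(/C=C/c1ccc(CN2C(=O)/C(=C3\Nc4ccccc4\C3=N/O)c3cccc(Cl)c32)cc1)NO` gives 90 nM
compound 2 `O=C(/C=C/c1ccc(CN2C(=O)/C(=C3\Nc4ccccc4\C3=N/O)c3cc(Cl)ccc32)cc1)NO` gives 60 nM
compound 3 `O=C(NO)c1ccc(CN2C(=O)/C(=C3\Nc4ccccc4\C3=N/O)c3cc(Cl)ccc32)cc1` gives 50 nM

In a functional assay on PC-3 cells (Homo sapiens) for cytotoxicity, read by colorimetric assay (on this read-out higher numbers stand for weaker inhibition and lower numbers for stronger inhibition), compound 3 gives 50 nM and lies within the usual scatter of compound 1 and compound 2, so no order among the three can be claimed. Compound 4 `COc1ccc2c(c1)/C(=C1/Nc3ccccc3/C1=N\O)C(=O)N2Cc1ccc(C(=O)NO)cc1` has not yet been measured. It has methoxy in place of chloro on an aromatic carbon of a six-membered aromatic ring of carbon only.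

Only one measured step connects two of these compounds (a 1.2-fold lower number from compound 2 to compound 3 (0.08 log units; within the scatter)) and it lies within the scatter. For the measured compounds named here, that step changes a different group, so it bears on this swap only indirectly, and no measured pair replaces chloro with methoxy. On this limited evidence, any shift in this assay is expected to stay within the scatter. The estimate stays close to compound 3 at 50 nM in this series. The estimated step is a 1.2-fold higher number from compound 3 to compound 4 (0.08 log units; within the scatter) and it stays within the scatter. As far as these compounds go, for compound 4 the estimated value is 60 nM with an expected range from 25 nM to 150 nM because the swap itself remains untested.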

Compound 4, half-maximal inhibitory concentration: 30 nM
Estimate against measurement, compound 4: 2.0-fold (0.30 log units) above; the range from low to high includes it.
By their numbers in this assay, from the lowest: compounds 4, 3, 2 and 1 (each within the scatter of the next, the first and the last beyond it).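

In this assay, putting methoxy in place of chloro on this aromatic carbon gives a 1.7-fold lower number from compound 3 to compound 4 (0.22 log units; within the scatter) and so the two compounds cannot be told apart. For the compounds shown here, this is the first measured swap at this place on the ring, and it shows that two heavy atoms with a hydrogen-bond acceptor can stand where one chlorine stood while the number stays within the scatter. Nothing measured here says why the two groups read alike.

As far as these compounds go, whether that holds for other groups at this place stays open, as an amine, a carboxylic acid or a longer chain such as ethoxy could read quite differently. From the compounds shown here alone, it is also open whether methoxy would read the same way when the ring carries 2-(hydroxycarbamoyl)ethenyl in place of hydroxycarbamoyl.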